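The source may hold more compounds than are shown below. What is called first, only, known or untested is meant among the compounds shown, and "the series" means these compounds.

Going by the values given here, in an ADME assay on L6 cells (Rattus norvegicus) for cytotoxicity (on this read-out lower numbers stand for stronger inhibition and higher numbers for weaker inhibition), compound 2 `N=C(N)c1cccc(-c2cc(-c3cccc(C(=N)N)c3[N+](=O)[O-])no2)c1` gives 177000 nM, the only true number available so far. Compound 1 `CC(C)NC(=N)c1ccc(-c2cc(-c3cccc(C(=N)NC(C)C)c3)no2)cc1` gives > 187000 nM, which is a limit of the assay and not a number. With so little data, compound 2 is the natural reference point for what follows.

Compound 3 `COc1c(C(=N)N)cccc1-c1cc(-c2cccc(C(=N)N)c2)on1` differs from compound 2 in one place: methoxy in place of nitro on an aromatic carbon. In words, this is methoxy in place of nitro on an aromatic carbon, and the rest of the structure stays the same. Among the compounds with values here, no measured pair of compounds shows what a change of this kind does in this assay, so any forecast is cautious. The expected change is small, probably within the usual scatter, with a slight lean towards stronger inhibition. The estimated size of this change is a 1.5-fold lower number from compound 2 to compound 3 (0.17 log units; within the scatter). For compound 3, the expected value is 120000 nM, with an estimated range of 40000 nM to 250000 nM.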

Compound 3, half-maximal inhibitory concentration: > 214000 nM
Compound 3 ended at the assay's limit; the forecaster's own chance of this, stated with the estimate: 30%; middle value at least 1.7-fold (0.25 log units) from the limit.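

Going by these compounds alone, replacing nitro with methoxy on this aromatic carbon, ortho to a group of 3 heavy atoms, gives an at least 1.2-fold higher number from compound 2 to compound 3 (0.08 log units; that floor lies within the scatter), the first measured step at this position. This step has only a floor and no exact size, and that floor does not separate the two compounds, so methoxy and nitro cannot be ranked here. Even so, methoxy shows no sign of the stronger inhibition in this assay that a clearly lower number would have meant, and the result for compound 3 is a limit of the assay: the limit of > 214000 nM in this assay, at which 1 of the 3 values shown sits.

The compounds shown leave open how large the true difference between methoxy and nitro is at this position. They also leave open whether an amine, a carboxylic acid or a longer chain such as ethoxy on the same carbon would give a clearly lower number than compound 2.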